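Methylamine to Ethylamine on Two Related Benzophenone-Type Cores

This account rests on a few compounds, and the source may have more. Where it says the series, first, only, none or still open, it means among the compounds named here.

Measured compounds:
Compound 1, `CNCC(=O)Nc1cc(OC)ccc1C(=O)c1ccc(OC)c2c1C=CC(C)(C)O2`, gives 1590 nM.
Compound 2, `CCNCC(=O)Nc1cc(OC)ccc1C(=O)c1ccc(OC)c2c1C=CC(C)(C)O2`, gives 4090 nM.
Compound 3, `C=C(c1ccc(OC)cc1NC(=O)CNC)c1ccc(OC)c2c1C=CC(C)(C)O2`, gives 720 nM.

All three were tested in a functional assay on A2780 cells (Homo sapiens) for antiproliferative activity, read by MTT assay, with a stated time of 48 h; on this read-out lower numbers stand for stronger inhibition and higher numbers for weaker inhibition. Compound 1 and compound 2 share one core and differ in a single place: methyl in place of hydrogen on a saturated chain carbon bound to an amine nitrogen. That change gave a 2.6-fold higher number from compound 1 to compound 2 (0.41 log units; beyond the scatter), so the larger amine substituent went with weaker inhibition of cell growth.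

Compound 3 carries the same methylamino side chain on a different core; the difference between the two cores is not broken down here. In this assay compound 3 gives the lowest of the three numbers, and its step to compound 1 and to compound 2 is beyond the usual scatter.

Compound 4, `C=C(c1ccc(OC)cc1NC(=O)CNCC)c1ccc(OC)c2c1C=CC(C)(C)O2`, has not yet been measured. It differs from compound 3 by methyl in place of hydrogen on a saturated chain carbon bound to an amine nitrogen, the same change that turns compound 1 into compound 2. Going by the values given here, the only guide to its size is the single earlier step, a 2.6-fold higher number from compound 1 to compound 2 (0.41 log units; beyond the scatter), measured on the other core; whether the second core responds alike is untested. Carrying that step over, the estimate for compound 4 in this assay is 1800 nM, most likely between 900 nM and 3800 nM. The expected step is a 2.5-fold higher number from compound 3 to compound 4 (0.40 log units; beyond the scatter), resting on compound 3 at 720 nM and on the earlier change.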

Compound 4, half-maximal inhibitory concentration: 2010 nM
Compound 4: middle estimate off by 1.1-fold (0.05 log units), on the low side; the measured number falls inside the stated range.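

On the second core the same methyl to ethyl change again raised the number, with a 2.8-fold higher number from compound 3 to compound 4 (0.45 log units; beyond the scatter) in this assay, and set beside the earlier step, the two agree: the same change on two cores in this assay, a 2.6-fold higher number (0.41 log units; beyond the scatter) from compound 1 to compound 2 and a 2.8-fold higher number (0.45 log units; beyond the scatter) from compound 3 to compound 4, 1.1-fold (0.04 log units) apart, within the scatter of two such steps. So within this small set, the change from methylamino to ethylamino weakened inhibition of cell growth to a similar extent on both cores, and neither pair goes against that pattern. Going by these compounds alone, this rests on only two matched pairs in one cell-based assay, so it does not show that the step would keep its size on any other core or that another change at this place would carry over as well, and it does not explain why the ethylamino compounds give the higher numbers.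

The compounds shown cover only the methylamino and ethylamino side chains, so it remains open how a primary amine, a longer chain such as propyl, a branched group such as isopropyl, or a ring amine such as pyrrolidine would behave at this place. As far as these compounds go, it also remains open whether any of these groups would shift the number by a similar amount on both cores, as the ethyl group does here.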